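The source may report more compounds than this note shows. Statements on the series, on what has been measured and on what is new or still open speak of the compounds shown alone.

Working notes on the series, read in an ADME assay on RAW264.7 cells (Mus musculus) for cytotoxicity, read by MTT assay, with a stated time of 24 h, in the absence of a further agent; on this read-out lower numbers stand for stronger inhibition and higher numbers for weaker inhibition. Compound 1 `O=C1OC(Cc2nc(-c3ccccc3)no2)c2ccccc21` gives > 40000 nM, which is a limit and not a number. Compound 2 `O=C1OC(Cc2nc(Cc3ccccc3)no2)c2ccccc21` gives > 40000 nM, which is also a limit. Compound 3 `CCCOc1ccc(C(O)C2OC(=O)c3c(OC)cc(OC)cc32)cc1` gives > 40000 nM, again a limit. All measured compounds stand at the limit of > 40000 nM in this assay, at which 3 of the 3 values shown sit, so compound 3 offers no number of its own as a starting point.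

Compound 4 `CCOCCOc1ccc(C(O)C2OC(=O)c3c(OC)cc(OC)cc32)cc1` is the next to be read. Its difference from compound 3 is ethoxy in place of methyl on a saturated chain carbon, two bonds along the chain from an oxygen on an aromatic ring. Cut one bond further out, the same difference reads propoxy to 2-ethoxyethoxy.

Among the compounds with values here, the only measured step is a step that the two limits leave unreadable from compound 1 to compound 2, with benzyl in place of phenyl on an aromatic carbon. That is a different change, and it gives no size to carry over. Within the data shown here, no measured step covers the change at hand, so no step beyond the scatter is expected in this assay, and no direction can be assigned. The expectation starts from compound 3 at > 40000 nM, a limit. The expected step is a step that the limit leaves unreadable from compound 3 to compound 4. A report as a limit is the likeliest outcome for the next reading. For compound 4 the estimate is 45000 nM, with an expected range from 20000 nM to 90000 nM.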

Compound 4, half-maximal inhibitory concentration: > 40000 nM
Compound 4: only a limit was reported (the forecaster's own chance of this, stated with the estimate: 85%); the middle value lies beyond the limit too.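

Compound 4 gives > 40000 nM, which is a limit and not a number. No step can be read between compound 3 and compound 4, as both are reported only as limits: the limit of > 40000 nM in this assay, at which 4 of the 4 values shown sit.

The compounds shown leave open how far each lies beyond that limit, and whether any change in this series would give a readable value.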